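A Trifluoromethyl Group Added to the Phenyl of Compound 1

The source may hold more compounds than are shown below. What is called first, only, known or untested is meant among the compounds shown, and "the series" means these compounds.

Compound 1 `c1ccc(-c2cn3ccnc3c(-c3ccc4ncn(C5CCCCC5)c4c3)n2)cc1` stands highest of the three measured compounds in a functional assay on OVCAR-8 cells (Homo sapiens) for inhibition, read by sulforhodamine B assay, with a stated time of 48 h, tested at 10 uM (on this read-out higher numbers stand for more inhibition at the one concentration tested (going by the name of the read-out) and lower numbers for less inhibition), where compound 1 gives 63.9%. Compound 2 `O=Cc1ccc(-c2cn3ccnc3c(-c3ccc4ncn(C5CCCCC5)c4c3)n2)cc1`, which carries a formyl group in place of a hydrogen on the phenyl, gives 44% in this assay. That step is a number 19.9 percentage points lower from compound 1 to compound 2 (beyond the scatter). Compound 3 `c1cn2cc(-c3ccsc3)nc(-c3ccc4ncn(C5CCCCC5)c4c3)c2n1`, in which thiophen-3-yl replaces the phenyl, gives 12.1% in this assay. That step is a number 51.8 percentage points lower from compound 1 to compound 3 (beyond the scatter). Compound 4 `FC(F)(F)c1cccc(-c2cn3ccnc3c(-c3ccc4ncn(C5CCCCC5)c4c3)n2)c1` has not yet been measured; it differs from compound 1 by trifluoromethyl in place of hydrogen on an aromatic carbon. The step from compound 1 to compound 2 is the closest comparison: it also adds a group to the phenyl, and it was modest. The step from compound 1 to compound 3 exchanges the whole ring and was large, so it speaks less directly to this change. A modest fall, or none beyond the scatter, is therefore expected, namely a number 13.9 percentage points lower from compound 1 to compound 4 (beyond the scatter). Compound 4 is estimated to give 50% in this assay, with a likely range from 25% to 75%.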

Compound 4, a percentage reported as inhibition, at one concentration (the size of the read-out at that concentration, not a potency): 10.1%
Estimate against measurement, compound 4: 39.9 percentage points above, and the stated range ends above it.
By their numbers in this assay, from the lowest: compounds 4 and 3 (each within the scatter of the next); then compound 2; then compound 1.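

In this assay, adding one trifluoromethyl group to the phenyl gives a number 53.8 percentage points lower from compound 1 to compound 4 (beyond the scatter), so a small addition at this position can matter as much as exchanging the whole ring, as the comparison with thiophen-3-yl shows: a number 2 percentage points lower from compound 3 to compound 4 (within the scatter). Compound 2 alone suggested that a group added to this phenyl brings only a modest fall, but compound 4 shows that this does not hold for every added group. The two substituted phenyls also stand well apart, with a number 33.9 percentage points lower from compound 2 to compound 4 (beyond the scatter).

Nothing measured here explains the size of this fall. 3-(Trifluoromethyl)phenyl and 4-formylphenyl differ in both the group and its place on the ring, so it remains open which of the two matters, and 4-(trifluoromethyl)phenyl, 3-formylphenyl or a phenyl carrying an amine would help to separate them.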